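The source may hold more compounds than are shown below. What is called first, only, known or untested is meant among the compounds shown, and "the series" means these compounds.

Compound 1 `Cc1ccc(OCC(=O)N2CCN(c3ccc(C(F)(F)F)cc3[C@@H](N)CC(C)C)CC2)cc1` gives 4400 nM in an assay on HEK293 cells for displacement of a labelled ligand from Melanocortin receptor 4 (Homo sapiens); a lower number here means a stronger inhibitor, a higher number a weaker inhibitor. Compound 2 `CC(C)C[C@H](N)c1cc(C(F)(F)F)ccc1N1CCN(C(=O)COc2ccc(O)cc2)CC1` gives 4600 nM in this assay; the move from compound 1 to compound 2 is a 1.0-fold higher number from compound 1 to compound 2 (0.02 log units; within the scatter). Going by the values given here, on the two numbers so far compound 2 stands level with compound 1, the only other measured compound, and the two are not separable.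

Compound 3 `Cc1ccc(CC(C)C(=O)N2CCN(c3ccc(C(F)(F)F)cc3[C@@H](N)CC(C)C)CC2)cc1C` is not yet measured. It differs from compound 2 as follows: 1-(3,4-dimethylbenzyl)ethyl in place of (4-hydroxyphenoxy)methyl on a carbonyl carbon

Among the compounds with values here, only one measured step exists, a 1.0-fold higher number from compound 1 to compound 2 (0.02 log units; within the scatter), and it concerns a hydroxy for a methyl on an aromatic carbon while the rest of the (4-hydroxyphenoxy)methyl arm was kept. Within the data shown here, the change to compound 3 replaces that whole arm, so no measured step covers it directly. Among the measured compounds shown here, the single step shows that a change on the aromatic ring of the arm left this assay unmoved, which argues for a modest step at most, but the direction cannot be read from the data. The expected step from compound 2 to compound 3 is a 1.2-fold lower number from compound 2 to compound 3 (0.06 log units; within the scatter), kept close to no change with a wide margin. Compound 3 is therefore estimated at 4000 nM, within 1200 nM to 14000 nM.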

Compound 3, inhibition constant: 240 nM
The estimate for compound 3 lay 17-fold (1.22 log units) above the measured number, and the stated range ends above it.
By their numbers in this assay, from the lowest: compound 3; then compounds 1 and 2 (each within the scatter of the next).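

In this assay the position on the carbonyl carbon, whose other neighbour is the amide-type nitrogen in a ring, turns out to be far more responsive than the earlier pair could show: 1-(3,4-dimethylbenzyl)ethyl in place of (4-hydroxyphenoxy)methyl gives a 19-fold lower number from compound 2 to compound 3 (1.28 log units; beyond the scatter), and the same group in place of (4-methylphenoxy)methyl gives an 18-fold lower number from compound 1 to compound 3 (1.26 log units; beyond the scatter). Compound 1 and compound 2 lie within the scatter of each other, so the large step appears from both starting arms, and it comes with an entering group that has no hydrogen-bond donors or acceptors and more heavy atoms than the arm of compound 2. No measurement at hand accounts for the size of this step.

The whole arm changes in one move, so the compounds shown do not separate the contribution of the branched carbon, the loss of the arm's oxygen and the two ring methyl groups. Also open, from the compounds shown here alone, is how this assay would read an unbranched 2-phenylethyl arm, or an arm bearing a chloro group or an amine on the ring.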